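Changing the aryl group on the amine of a quinone core

The source may hold more compounds than are shown below. What is called first, only, known or untested is meant among the compounds shown, and "the series" means these compounds.

Measured compounds:
compound 1, `O=C1C(N2CCCCC2)=CC(=O)c2c1nc1n2[C@H]2OC[C@@H](O)[C@H]2OC1`, > 16000 nM
compound 2, `COc1ccccc1NC1=CC(=O)c2nc3n(c2C1=O)[C@H]1OC[C@@H](O)[C@H]1OC3`, 2950 nM

In a functional assay on HeLa cells (Homo sapiens) for inhibition, read by sulforhodamine B assay (a lower number here means a stronger inhibitor, a higher number a weaker inhibitor), compound 1 gives only a limit of the assay, > 16000 nM. For the measured compounds named here, compound 2, the same core carrying a (2-methoxyphenyl)amino group, gives 2950 nM in this assay; this is the only real number among the two measured compounds, the other value being (the limit of > 16000 nM in this assay, at which 1 of the 2 values shown sits).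

Compound 3, `O=C1C=C(Nc2ccc(I)cc2)C(=O)c2c1nc1n2[C@H]2OC[C@@H](O)[C@H]2OC1`, keeps the core of compound 2 and differs in one place: 4-iodophenyl in place of 2-methoxyphenyl on an amine nitrogen. Going by the values given here, no measured pair of compounds shows what such a swap does here, so the size of the step from compound 2 to compound 3 in this assay is uncertain; it is expected to be modest, a 1.5-fold lower number from compound 2 to compound 3 (0.17 log units; within the scatter), and not clearly beyond the scatter in either direction. Compound 3 is therefore estimated at 2000 nM, within a range of 500 nM to 8000 nM.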

Compound 3, half-maximal inhibitory concentration: 4070 nM
Compound 3: middle estimate off by 2.0-fold (0.31 log units), on the low side; the measured number falls inside the stated range.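

In this assay, for the compounds shown here, this is the first measured pair that differs in one place, and the swap gives a 1.4-fold higher number from compound 2 to compound 3 (0.14 log units; within the scatter). On this amine nitrogen, then, the two values cannot be told apart, even though the groups differ: 2-methoxyphenyl carries an oxygen and 4-iodophenyl carries an iodine. Nothing measured here offers a reason for this result.

From the compounds shown here alone, what a plain phenyl group, a pyridine ring or a benzyl group would give on this amine nitrogen remains open. Also open, going by these compounds, is whether any single swap at this place can move the number beyond the scatter, since one pair of aryl groups cannot show how much the number responds to changes here.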